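This account rests on a few compounds, and the source may have more. Where it says the series, first, only, none or still open, it means among the compounds named here.

Measured so far:
Compound 1, `CCC(CC)O[C@@H]1C=C(C(=O)O)C[C@H](NCc2ccc(C(C)C)cc2)[C@H]1NC(C)=O`: > 200000 nM
Compound 2, `CCC(CC)O[C@@H]1C=C(C(=O)O)C[C@H](NCc2ccc(SC(C)CC)cc2)[C@H]1NC(C)=O`: > 200000 nM

In an ADME assay on cells (Fibroblast, Gallus gallus) for cytotoxicity, read by CCK-8 assay, with a stated time of 48 h (a lower number here means that less compound is tolerated, a higher number that more compound is tolerated), compound 1 gives > 200000 nM, which is a limit of the assay rather than a number. Compound 2 gives > 200000 nM, also a limit. The step that the two limits leave unreadable from compound 1 to compound 2 cannot be read because both values sit at the limit of > 200000 nM in this assay, at which 2 of the 2 values shown sit. Among the measured compounds shown here, compound 2 thus stands at the limit, with no number of its own and no second compound to place it against.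

Compound 3, `CCC(CC)O[C@@H]1C=C(C(=O)O)C[C@H](NCc2ccc(-c3ccc4sccc4c3)cc2)[C@H]1NC(C)=O`, has not yet been measured in this assay. Against compound 2 the change is 1-benzothiophen-5-yl in place of (sec-butyl)sulfanyl on an aromatic carbon. No measured step can be read, so none bears on this change, and the data give no reason to expect a step in either direction beyond the scatter. Compound 3 is therefore estimated at 200000 nM, with a range from 50000 nM to 400000 nM. This estimate means an expected step of a number no higher from compound 2 to compound 3 (the limit leaves the size open).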

Compound 3, half-maximal cytotoxic concentration: > 200000 nM
Compound 3: only a limit was reported (the forecaster's own chance of this, stated with the estimate: 60%); the middle value sits exactly at the limit.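

No step among compound 1, compound 2 and compound 3 can be read, because all three results are limits rather than numbers: the limit of > 200000 nM in this assay, at which 3 of the 3 values shown sit.

The compounds shown leave open where each true value lies, and whether isopropyl, (sec-butyl)sulfanyl and 1-benzothiophen-5-yl differ in their effect on the cells at all.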